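The source may report more compounds than this note shows. Statements on the series, on what has been measured and on what is new or still open speak of the compounds shown alone.

Compound 2, whose structure is `C=CC(=O)N1CC[C@H](N2C(=O)N(c3ccccc3)Cc3cnc(Nc4ccc(N5CCN(C)CC5)cc4)nc32)C1`, was tested in an ADME assay on the whole organism (plasma, strain Sprague-Dawley) for pharmacokinetics, with Rattus norvegicus as the target, read by LC-MS, at a dose of 25 mg/kg by the oral route (on this read-out higher numbers stand for higher exposure at the dose given and lower numbers for lower exposure), and gave 2310 ng.h/mL. Within the data shown here, its only measured neighbour is compound 1, with structure `C=CC(=O)N1CC[C@H](N2C(=O)N(c3ccccc3)Cc3cnc(Nc4ccc(C5CCN(C)CC5)cc4)nc32)C1`, which in this assay gave 1310 ng.h/mL; the difference, a 1.8-fold higher number from compound 1 to compound 2 (0.25 log units; within the scatter), means the two compounds cannot be told apart on this read-out. The next compound, compound 3, has the structure `C=CC(=O)N1CC[C@H](N2C(=O)N(c3ccccc3)Cc3cnc(Nc4ccccc4)nc32)C1`. It differs from compound 2 by hydrogen in place of 4-methylpiperazin-1-yl on an aromatic carbon. Among the measured compounds shown here, the single measured step, a 1.8-fold higher number from compound 1 to compound 2 (0.25 log units; within the scatter), swaps one ring group for another and does not remove the group altogether, so it offers no direct guide to the change toward compound 3, and nothing among the measured pairs says that this position governs exposure. Compound 3 is therefore expected to give 1500 ng.h/mL in this assay, between 500 ng.h/mL and 4500 ng.h/mL, a step of a 1.5-fold lower number from compound 2 to compound 3 (0.19 log units; within the scatter) that is estimated to stay near the scatter.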

Compound 3, area under the concentration-time curve: 4520 ng.h/mL
Compound 3: the middle estimate sits 3.0-fold (0.48 log units) below what was measured, outside the stated range (above it).
By their numbers in this assay, from the lowest: compounds 1, 2 and 3 (each within the scatter of the next, the first and the last beyond it).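

Replacing the ring group with plain hydrogen shows that exposure in this assay does not depend on a large basic-free substituent at this place, on an aromatic carbon para to a large group: the change gives a 2.0-fold higher number from compound 2 to compound 3 (0.29 log units; within the scatter) and stays inside the usual noise. Among these compounds, measured against the other ring group, 1-methylpiperidin-4-yl, the same replacement gives a 3.5-fold higher number from compound 1 to compound 3 (0.54 log units; beyond the scatter) and is the only step here to clear the scatter, though it is modest. Nothing measured here accounts for these numbers.

Going by these compounds, whether a small group at this place, such as methoxy, a primary amine or a carboxylic acid, would sit with the hydrogen or with the ring groups remains open. So does whether the same replacement behaves alike on a core carrying something other than the phenyl group.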